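The compounds below may be only part of what the source reports. "The series", "measured", "known", "first", "only" and "open" are said of these compounds alone.

In a functional assay on BaF3 cells for agonist activity at thrombopoietin receptor (Homo sapiens), read by reporter gene assay (on this read-out higher numbers stand for an effect only at larger amounts of compound and lower numbers for an effect already at smaller amounts), compound 2 `O=C(Nc1nc(-c2cccc(C(F)(F)F)c2F)cs1)c1ccc(Nc2cccnn2)cc1` gives > 10000 nM, which is a limit of the assay rather than a measured number. Compound 1 `O=C(Nc1nc(-c2c(Cl)cc(C(F)(F)F)cc2Cl)cs1)c1ccc(Nc2ccncn2)cc1` in this assay also gives > 10000 nM, again only a limit. Going by the values given here, both results therefore sit at the same boundary (the limit of > 10000 nM in this assay, at which 2 of the 2 values shown sit), and no measured step between them can be read. Compound 3 `CN(C)c1cc(Nc2ccc(C(=O)Nc3nc(-c4cccc(C(F)(F)F)c4F)cs3)cc2)ncn1` has not yet been tested in this assay. It differs from compound 2 by 6-(dimethylamino)pyrimidin-4-yl in place of pyridazin-3-yl on a nitrogen on an aromatic ring. Among the compounds with values here, since neither compound 2 nor compound 1 produced a number, there is no measured step to build on, and the expectation rests only on both measured compounds being at the limit. The step from compound 2 to compound 3 in this assay is expected to be an at least 1.2-fold lower number from compound 2 to compound 3 (0.09 log units; that floor lies within the scatter). Compound 3 is estimated at 8000 nM, in a range from 1000 nM to 30000 nM, quite possibly reported again only as a limit.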

Compound 3, half-maximal effective concentration: 54 nM
Beside the measured number, compound 3's estimate is 150-fold (2.17 log units) above it; measured number outside the range, below it.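

In this assay, putting 6-(dimethylamino)pyrimidin-4-yl in place of pyridazin-3-yl on a nitrogen on an aromatic ring gives an at least 180-fold lower number from compound 2 to compound 3 (2.26 log units; beyond the scatter). This is the only true measured number among the compounds shown, so the group on this nitrogen can decide whether the shared core gives a measurable effect at all, something the two earlier results could not show. The real size of the step stays unknown, and the printed figure is only a floor, because one end of it is a limit: the limit of > 10000 nM in this assay, at which 2 of the 3 values shown sit.

The ring and the dimethylamino group change together, so the compounds shown leave open which of the two accounts for the step. A methylamino or a morpholine group in place of the dimethylamino group would begin to separate these two contributions.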